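The source may report more compounds than this note shows. Statements on the series, on what has been measured and on what is new or still open speak of the compounds shown alone.

Among the measured compounds shown here, only one of the three compounds measured so far has a real number. In a functional assay on HeLa cells (Homo sapiens) for antiproliferative activity, read by sulforhodamine B assay (on this read-out higher numbers stand for weaker inhibition of growth and lower numbers for stronger inhibition of growth), compound 3 `O[C@@H]1[C@@H](OCc2ccccc2)[C@H](OCc2ccccc2)[C@@H](COCc2ccccc2)O[C@H]1Cc1ccccc1` gives 17400 nM. Compound 1 `O[C@H]1CO[C@H](COCc2ccccc2)[C@@H](OCc2ccccc2)[C@@H]1OCc1ccccc1` sits at > 50000 nM, which is a limit of the assay and not a number. Compound 2 `CC(C)C[C@@H]1O[C@H](COCc2ccccc2)[C@@H](OCc2ccccc2)[C@H](OCc2ccccc2)[C@H]1O` sits at > 50000 nM, which is also a limit.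

The next compound, compound 4 `O[C@@H]1[C@@H](O)[C@H](Cc2ccccc2)O[C@H](COCc2ccccc2)[C@H]1OCc1ccccc1`, differs from compound 3 in one place: hydrogen in place of benzyl on an oxygen on a saturated carbon. This puts hydrogen in place of benzyl on an oxygen on a saturated carbon, so a benzyloxy becomes a hydroxy.

For the measured compounds named here, no measured step makes this exact change, so the evidence is indirect. The closest guide is an at least 2.8-fold lower number from compound 1 to compound 3 (0.45 log units; beyond the scatter), where a benzyl in place of hydrogen on a saturated ring carbon went with stronger inhibition of growth. Also relevant is an at least 2.8-fold lower number from compound 2 to compound 3 (0.45 log units; beyond the scatter), which likewise favours the compound carrying the phenyl. Neither step involves a benzyl on an oxygen, so they support only a cautious expectation: losing a benzyl should move the number up modestly in this assay, and a reading at the limit is quite possible.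

The expected change is a 1.7-fold higher number from compound 3 to compound 4 (0.24 log units; within the scatter). For compound 4 the estimate is 30000 nM, with an expected range from 10000 nM to 70000 nM.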

Compound 4, concentration for 50% growth inhibition: 47900 nM
Compound 4: the middle estimate sits 1.6-fold (0.20 log units) below what was measured, and the stated range covers the measured number.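

This is the first step shown that changes a group on one of the oxygens while the rest of the molecule stays the same, so this position now has a direct reading instead of an indirect one. In this assay the change from benzyloxy to hydroxy gives a 2.8-fold higher number from compound 3 to compound 4 (0.44 log units; beyond the scatter) and so a modest weakening of growth inhibition, which shows that the benzyl on this oxygen contributes to the activity of compound 3 and that a hydroxy there does not fully make up for its loss. Compound 4 still gives a real number, but that number lies close to the end of the scale: the limit of > 50000 nM in this assay, at which 2 of the 4 values shown sit.

Going by these compounds, only benzyl and hydrogen appear on this oxygen, so it remains open whether a smaller group such as methyl, or a longer chain such as n-butyl, would behave more like the benzyl or more like the hydrogen. On these data alone, it also remains open whether taking the benzyl off either of the other two oxygens would weaken growth inhibition to the same degree.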